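The source may hold more compounds than are shown below. What is called first, only, known or untested is meant among the compounds shown, and "the series" means these compounds.

Compound 1: `O=C(NNc1ccnc2cc(Cl)ccc12)c1ccccc1/N=C/c1ccccc1Cl`, 5.5
Compound 2: `COc1ccc(/C=N/c2ccccc2C(=O)NNc2ccnc3cc(Cl)ccc23)cc1OC`, 4.97

In a physicochemical assay for lipophilicity, measured as octanol-water partition (on this read-out higher numbers stand for higher lipophilicity and lower numbers for lower lipophilicity), compound 2, at 4.97, is the lower of the two measured compounds, beneath compound 1. Next comes compound 3 `O=C(NNc1ccnc2cc(Cl)ccc12)c1ccccc1/N=C/c1ccc([N+](=O)[O-])cc1`, with this change: 4-nitrophenyl in place of 3,4-dimethoxyphenyl on a carbon with a double bond to nitrogen. For the measured compounds named here, only one measured step bears on it, a number 0.53 log units lower from compound 1 to compound 2 (beyond the scatter), a modest step on the same carbon with a double bond to nitrogen. That step does not involve 4-nitrophenyl, so it gives no firm direction, and no change beyond the scatter is expected. The expected step is a number 0.03 log units higher from compound 2 to compound 3 (within the scatter). The estimated value for compound 3 is 5, with an expected range of 4.6 to 5.4.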

Compound 3, partition coefficient: 4.58
Estimate against measurement, compound 3: 0.42 log units above; the whole stated range lies above it.
By their numbers in this assay, from the lowest: compound 3; then compound 2; then compound 1.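

For the compounds shown here, with 4-nitrophenyl on the carbon with a double bond to nitrogen, compound 3 sets the lowest number so far in this assay, with a number 0.39 log units lower from compound 2 to compound 3 (beyond the scatter) and a number 0.92 log units lower from compound 1 to compound 3 (beyond the scatter) as the two steps that reach it. This place therefore moves the number further than the earlier pair showed, yet 3,4-dimethoxyphenyl and 4-nitrophenyl have the same counts of hydrogen-bond donors and acceptors, so those counts do not separate them. No measurement shown explains these differences.

From the compounds shown here alone, how a phenyl carrying an amine or a carboxylic acid would stand at this place remains open.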